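Removing the methoxymethyl group from compound 1

The source may report more compounds than this note shows. Statements on the series, on what has been measured and on what is new or still open speak of the compounds shown alone.

Values in a functional assay on MCF7 cells (Homo sapiens) for antiproliferative activity, read by MTT assay (on this read-out lower numbers stand for stronger inhibition and higher numbers for weaker inhibition), each of them a limit of the assay:
- compound 1 `CCCCC/C=C\C/C=C\CCCCCCCc1cc(=O)c2c(O)c(C)c(OCOC)c(C)c2o1`: > 84100 nM
- compound 2 `CCCC/C=C\CCCCCCCCCc1cc(=O)c2c(O)c(C)c(OCOC)c(C)c2o1`: > 67200 nM
- compound 3 `CCCCC/C=C\C/C=C\CCCCCCCc1cc(=O)c2c(O)cc(OCOC)c(C)c2o1`: > 84100 nM

None of these three compounds has a true number. Compound 1 stands at the limit of > 84100 nM in this assay, at which 2 of the 3 values shown sit.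

The next compound, compound 4 `CCCCC/C=C\C/C=C\CCCCCCCc1cc(=O)c2c(O)c(C)c(O)c(C)c2o1`, has hydrogen in place of methoxymethyl on an oxygen on an aromatic ring, so methoxymethoxy becomes hydroxy: hydrogen in place of methoxymethyl on an oxygen on an aromatic ring.

Two measured steps start from compound 1. Putting oct-3-en-1-yl in place of deca-1,4-dien-1-yl gives a step that the two limits leave unreadable from compound 1 to compound 2. Putting hydrogen in place of methyl on an aromatic carbon gives a step that the two limits leave unreadable from compound 1 to compound 3. Neither size can be read, and neither step touches the methoxymethoxy group, which all three compounds keep. The measurements therefore offer no size to carry over to this change.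

The estimate rests on little, and another limit is about as likely as a number. If a number does appear, it can only be expected on the side of stronger inhibition, and the expected change is modest, given as an at least 1.6-fold lower number from compound 1 to compound 4 (0.22 log units; that floor lies within the scatter). For compound 4 the estimated value is 50000 nM, with an expected range from 12000 nM to 92000 nM.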

Compound 4, half-maximal inhibitory concentration: > 84100 nM
Compound 4: no number, only a limit; the forecaster's own chance of this, stated with the estimate: 50%; middle value at least 1.6-fold (0.22 log units) away from the limit.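

In this assay compound 4 gives > 84100 nM, which is a limit of the assay and not a number. Compound 1 also has only a limit, so no step can be read between compound 1 and compound 4. The compounds shown leave open whether hydrogen in place of methoxymethyl, or any other change here, alters inhibition at all.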